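Swapping the pyrazole on a shared bicyclic core

The compounds below may be only part of what the source reports. "The series", "measured", "known", "first", "only" and "open" are said of these compounds alone.

Measured so far:
Compound 1 `Cn1ccc(-c2cccc3c2CCC3c2ncc[nH]2)n1` in a functional assay on CHO cells for agonist activity at Alpha-1B adrenergic receptor (Homo sapiens), read by FLIPR and calcium flux (a lower number here means that less compound is needed, a higher number that more compound is needed for the effect), gives > 10000 nM, a limit of the assay and not a number.
Compound 2 `CS(=O)(=O)Nc1cccc2c1CCCC2c1ncc[nH]1` in this assay gives > 10000 nM; > 10000 nM; > 10000 nM (3 entries), again only a limit of the assay.

Compound 1 therefore stands at the limit of > 10000 nM in this assay, at which 1 of the 2 values shown sits, so no true number is known for it. Compound 3 `c1cc(-c2cn[nH]c2)c2c(c1)C(c1ncc[nH]1)CC2` differs from compound 1 by 1H-pyrazol-4-yl in place of 1-methyl-1H-pyrazol-3-yl on an aromatic carbon. Within the data shown here, no measured step exists here, so nothing shows how this change moves the result; a step of any size in either direction remains possible, though both known compounds sit at the limit. Compound 3 is expected to give about 12000 nM, between 3000 nM and 50000 nM. The expected step that the limit leaves unreadable from compound 1 to compound 3 is thus none beyond the scatter.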

Compound 3, half-maximal effective concentration: > 10000 nM
Compound 3: only a limit was reported; the forecaster's own chance of this, stated with the estimate: 70%; the middle value is on the limit's open side.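

Among these compounds, compound 1 and compound 3 both sit at a limit of the assay and not at a number, so no step between them can be read: the limit of > 10000 nM in this assay, at which 2 of the 3 values shown sit. Going by these compounds, whether 1H-pyrazol-4-yl in place of 1-methyl-1H-pyrazol-3-yl changes the true value at all stays open.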